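Swapping the bicyclic side group for a small trifluoromethyl triazole

The source may hold more compounds than are shown below. What is called first, only, known or untested is meant among the compounds shown, and "the series" means these compounds.

Of the compounds shown here, two have been measured in a functional assay on CHO-K1 cells for antagonist activity at C-X-C chemokine receptor type 3 (Homo sapiens), read by FLIPR, with a stated time of 10 min; on this read-out lower numbers stand for stronger inhibition and higher numbers for weaker inhibition. Compound 1 `C[C@@H]1CN(c2sc(CN(C)C)nc2-c2nc3ccccc3[nH]2)CCN1C(=O)Cn1cnc2cccnc21` gives 50 nM. Compound 2 `CCOc1ncc(-c2nc(C(F)(F)F)sc2N2CCN(C(=O)Cn3ccc4cccnc43)[C@H](C)C2)cn1` gives 3.8 nM, the lower of the two numbers, and its gap to compound 1 lies beyond the usual scatter, so compound 2 is the stronger inhibitor of the pair.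

Compound 3 `CCOc1ncc(-c2nc(C(F)(F)F)sc2N2CCN(C(=O)Cn3cnc(C(F)(F)F)n3)[C@H](C)C2)cn1` keeps the whole core of compound 2 and changes only the group attached to the saturated chain carbon bound to the carbonyl carbon: a group of 9 heavy atoms (3 carbon, 3 nitrogen, 3 fluorine; one five-membered aromatic ring with 3 hetero atoms) in place of a group of 9 heavy atoms (7 carbon, 2 nitrogen; one five-membered aromatic ring with 1 hetero atom, one six-membered aromatic ring with 1 hetero atom), on a saturated chain carbon bound to a carbonyl carbon. Among the measured compounds shown here, no pair of measured compounds shows this kind of exchange, so there is no measured step to lean on; the expectation rests on compound 2 alone.

Since the part that is exchanged is of the same size but of quite different make-up, some shift in the number seems likely, and the guess is a moderate move toward weaker inhibition. The expected step from compound 2 to compound 3 in this assay is a 3.2-fold higher number from compound 2 to compound 3 (0.50 log units; beyond the scatter). Compound 3 is thus estimated at 12 nM in this assay, within a range from 3 nM to 50 nM.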

Compound 3, half-maximal inhibitory concentration: 3.8 nM
The estimate for compound 3 lay 3.2-fold (0.50 log units) above the measured number; the range from low to high includes it.
By their numbers in this assay, from the lowest: compounds 2 and 3 (each within the scatter of the next); then compound 1.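

In this assay, putting 3-(trifluoromethyl)-1H-1,2,4-triazol-1-yl in place of the group with two aromatic rings gives no change at the digits printed from compound 2 to compound 3 (within the scatter). So on this saturated chain carbon bound to a carbonyl carbon, two groups of very different make-up, which share only their count of heavy atoms, give matching numbers: one has a single five-membered aromatic ring with three hetero atoms and three fluorines, the other a five-membered and a six-membered aromatic ring. This one exchange shows that the two-ring group is not needed at this place for a number this low on this core, but no measurement shown here explains why the two groups match.

Going by these compounds, whether the 1,2,4-triazole ring without its trifluoromethyl group would give the same number stays open, as does the outcome for a dimethylamino group or a carboxylic acid on the same carbon. It is also unknown whether the exchange would have the same outcome on the core of compound 1, which differs from compound 2 in more than one place.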